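From carboxy to hydroxymethyl on the shared core

The compounds below may be only part of what the source reports. "The series", "measured", "known", "first", "only" and "open" are said of these compounds alone.

Measured in a functional assay on RAW264.7 cells (Mus musculus) for inhibition, read by Griess assay, with stated times of 2 h and 18 h; a higher number here means a weaker inhibitor, a lower number a stronger inhibitor:
- Compound 1 `C[C@@H]1[C@@H](O)C(=O)[C@H]2C(C)(C)CCC[C@]2(C)[C@@]1(O)CCc1ccoc1`: > 50000 nM, a limit of the assay and not a number
- Compound 2 `CC1=CC[C@@H]2[C@](C)(CCC[C@]2(C)C=O)[C@H]1CC/C(C)=C/CO`: 29000 nM
- Compound 3 `CC1=CC[C@@H]2[C@](C)(CCC[C@]2(C)C(=O)O)[C@H]1CC/C(C)=C/CO`: 41100 nM

Only two of these compounds have a true number, and compound 3, at 41100 nM, lies within the scatter of compound 2. For the measured compounds named here, compound 1 offers only its limit, so it gives no size of step to work from.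

The next compound to be tested is compound 4 `CC1=CC[C@H]2[C@@](C)(CO)CCC[C@]2(C)[C@H]1CC/C(C)=C/CO`, which carries hydroxymethyl in place of carboxy on a saturated ring carbon. Going by the values given here, one measured step bears on this group: a 1.4-fold higher number from compound 2 to compound 3 (0.15 log units; within the scatter). That step puts hydroxy in place of hydrogen on a carbonyl carbon, and it is small. Among the compounds with values here, with a 1.4-fold higher number from compound 2 to compound 3 (0.15 log units; within the scatter) as the only guide, no step beyond the scatter is expected in this assay. The expected result is a 1.3-fold lower number from compound 3 to compound 4 (0.11 log units; within the scatter). Compound 4 is estimated at 32000 nM, with an expected range of 14000 nM to 50000 nM.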

Compound 4, half-maximal inhibitory concentration: 33400 nM
Compound 4: middle estimate off by 1.0-fold (0.02 log units), on the low side; the range from low to high includes it.
By their numbers in this assay, from the lowest: compounds 2, 4 and 3 (each within the scatter of the next). At a limit, above all of these: compound 1.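

In this assay, the saturated ring carbon of the shared core has now carried formyl, carboxy and hydroxymethyl, and no one of these three sets itself apart. Hydroxymethyl in place of carboxy gives a 1.2-fold lower number from compound 3 to compound 4 (0.09 log units; within the scatter), and hydroxymethyl in place of formyl gives a 1.2-fold higher number from compound 2 to compound 4 (0.06 log units; within the scatter). The earlier compounds shown here showed only the exchange of formyl for carboxy, whereas compound 4 extends the same flat picture to a third group at this position and to a change that removes the carbonyl.

Going by these compounds, what an amine or a longer chain on this carbon would do to the number remains open. Compound 1 is a limit and not a number, and no step to it can be read: the limit of > 50000 nM in this assay, at which 1 of the 4 values shown sits.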